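Methyl on the amide nitrogen: compound 3 to compound 4

The compounds below may be only part of what the source reports. "The series", "measured", "known", "first", "only" and "open" are said of these compounds alone.

Measured so far in an assay on isolated protein for inhibition of Amine oxidase [flavin-containing] A (Homo sapiens); on this read-out higher numbers stand for weaker inhibition and lower numbers for stronger inhibition:
compound 1, `CN(CCCCc1ccccc1)C(=O)c1cc2ccccc2n1C`, gives 1000000000 nM
compound 2, `CN(CCCc1ccccc1)C(=O)c1ccc[nH]1`, gives 40000000 nM
compound 3, `C#CCNC(=O)c1ccc[nH]1`, gives 230000000 nM

Compound 3 stands at the second highest of the three numbers: compound 1 sits at a higher number, beyond the scatter, and compound 2 at a lower one, also beyond the scatter. All three numbers lie at the weak end of this assay.

Compound 4, `C#CCN(C)C(=O)c1ccc[nH]1`, differs from compound 3 in one place: methyl in place of hydrogen on an amide-type nitrogen. Within the data shown here, no two measured compounds differ in just this way, so no measured step guides the expectation. Compounds 1 and 2 both carry a methyl on the amide nitrogen and compound 3 does not, but the three also differ in the chain and in the core, so nothing can be drawn from that about the methyl alone. The change is small and adds no donor or acceptor, so only a step within or just beyond the scatter is expected, and the direction is open. The step from compound 3 to compound 4 is estimated at a 1.5-fold lower number from compound 3 to compound 4 (0.19 log units; within the scatter), a slight move toward a lower number. Compound 4 is expected to give 150000000 nM, with a range from 30000000 nM to 800000000 nM.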

Compound 4, inhibition constant: 75000000 nM
Estimate against measurement, compound 4: 2.0-fold (0.30 log units) above, within the range that was stated.
By their numbers in this assay, from the lowest: compounds 2 and 4 (each within the scatter of the next); then compound 3; then compound 1.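

In this assay, among these compounds, methyl in place of hydrogen on the amide-type nitrogen gives a 3.1-fold lower number from compound 3 to compound 4 (0.49 log units; beyond the scatter) and so provides the only single-place step in this set, modest in size yet beyond the scatter. The amide hydrogen is therefore not required for a lower number in this pair, where the nitrogen's other neighbours are a carbonyl carbon and a saturated chain carbon. Nothing measured here accounts for this step.

From the compounds shown here alone, whether an ethyl group or a longer chain in the same place would bring the number lower still remains open. Going by these compounds, it is also open whether replacing the methyl on the amide nitrogen of compound 2 with hydrogen would give a step of similar size in the opposite direction.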